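The source may hold more compounds than are shown below. What is called first, only, known or untested is meant among the compounds shown, and "the series" means these compounds.

Compound 1 `C[C@@H]1CN(c2scnc2-c2nc3ccccc3[nH]2)CCN1C(=O)Cn1cnc2cccnc21` gives 554 nM in an assay on blood for inhibition of C-X-C chemokine receptor type 3 (Homo sapiens), with a stated time of 30 min; a higher number here means a weaker inhibitor, a lower number a stronger inhibitor. Compound 2 `CC[C@@H]1CN(c2scnc2-c2nc3ccccc3[nH]2)CCN1C(=O)Cn1cnc2cccnc21` gives 851 nM in this assay. The change between them is methyl in place of hydrogen on a saturated chain carbon bound to a saturated ring carbon and it made a 1.5-fold higher number from compound 1 to compound 2 (0.19 log units; within the scatter). Compound 3 `CCc1ncc(-c2nc(C(F)(F)F)sc2N2CCN(C(=O)Cn3nc(C)nc3C)[C@H](C)C2)cn1` is built on another core; the difference between the two cores is not broken down here. In this assay compound 3 gives 567 nM, a number within the scatter of both compound 1 and compound 2. Compound 4 `CCCc1ncc(-c2nc(C(F)(F)F)sc2N2CCN(C(=O)Cn3nc(C)nc3C)[C@H](C)C2)cn1` carries the same kind of change as compound 2 carries over compound 1: methyl in place of hydrogen on a saturated chain carbon, two bonds along the chain from an aromatic carbon. The place differs: in compound 2 the carbon is bound to a saturated ring carbon, in compound 4 it is two bonds along the chain from an aromatic carbon. With a single earlier case to go on, the expected step is a 1.4-fold higher number from compound 3 to compound 4 (0.15 log units; within the scatter), set beside a 1.5-fold higher number from compound 1 to compound 2 (0.19 log units; within the scatter), and rests on that one step alone. On that basis compound 4 is estimated at 800 nM in this assay, with an expected range of 350 nM to 1900 nM.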

Compound 4, half-maximal inhibitory concentration: 367 nM
The estimate for compound 4 lay 2.2-fold (0.34 log units) above the measured number; the range from low to high includes it.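

Going from 2-ethylpyrimidin-5-yl to 2-propylpyrimidin-5-yl gives a 1.5-fold lower number from compound 3 to compound 4 (0.19 log units; within the scatter) in this assay. Set beside the earlier case, the two steps carry opposite signs, yet they do not separate from each other: the same change on two cores in this assay, a 1.5-fold higher number (0.19 log units; within the scatter) from compound 1 to compound 2 and a 1.5-fold lower number (0.19 log units; within the scatter) from compound 3 to compound 4, 2.4-fold (0.38 log units) apart, within the scatter of two such steps. Neither step stands clear of the scatter, so the pair does not show that the change carries from one core to the other, nor that it fails to, and the two cases also differ in place.

From the compounds shown here alone, whether a longer chain such as butyl, a branched chain such as isopropyl, or a chain ending in an amine or a carboxylic acid would move the number at this place remains open. Also open, going by these compounds, is how 2-propylpyrimidin-5-yl would read on the core of compound 1.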